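The source may hold more compounds than are shown below. What is called first, only, known or untested is meant among the compounds shown, and "the series" means these compounds.

For the measured compounds named here, compound 2 `FC(F)(F)c1ccc(C2=NN(C(=S)Nc3ccccc3)C(c3ccc4c(c3)OCCO4)C2)cc1` gives 52400 nM in a functional assay on WM 266-4 cells (Homo sapiens) for antiproliferative activity, read by MTT assay, with a stated time of 48 h (on this read-out higher numbers stand for weaker inhibition of growth and lower numbers for stronger inhibition of growth), the highest of the two numbers measured so far. Its nearest neighbour is compound 1 `Fc1ccc(C2=NN(C(=S)Nc3ccccc3)C(c3ccc4c(c3)OCCO4)C2)cc1`, which gives 22500 nM in this assay; the change of trifluoromethyl in place of fluoro on an aromatic carbon went a 2.3-fold higher number from compound 1 to compound 2 (0.37 log units; beyond the scatter). Compound 3 `COc1ccccc1C1=NN(C(=S)Nc2ccccc2)C(c2ccc3c(c2)OCCO3)C1` is the next compound, and it differs from compound 2 in that (2-methoxyphenyl in place of 4-(trifluoromethyl)phenyl on a carbon with a double bond to nitrogen). Going by the values given here, the one measured step bears only loosely on this change, since it concerned the aryl group on the same carbon but exchanged one substituent for another rather than introducing a methoxy. As the trifluoromethyl analogue gave the higher number, compound 3 is expected to move back toward compound 1, so that the step of a 1.7-fold lower number from compound 2 to compound 3 (0.24 log units; within the scatter) is expected to be modest and downward, with considerable uncertainty. Compound 3 is therefore estimated at 30000 nM in this assay, within a range from 10000 nM to 90000 nM.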

Compound 3, concentration for 50% growth inhibition: 25800 nM
For compound 3 the middle estimate is 1.2-fold (0.07 log units) above the measured one; the range from low to high includes it.
By their numbers in this assay, from the lowest: compounds 1 and 3 (each within the scatter of the next); then compound 2.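

In this assay the exchange of 4-(trifluoromethyl)phenyl for 2-methoxyphenyl gave a 2.0-fold lower number from compound 2 to compound 3 (0.31 log units; beyond the scatter) and showed that the number at this position can come back down with a substituent other than fluoro. The exchange of 4-fluorophenyl for 2-methoxyphenyl gave a 1.1-fold higher number from compound 1 to compound 3 (0.06 log units; within the scatter) and so left these two compounds level, although both the substituent and its place on the phenyl ring differ. Among the three compounds, only the trifluoromethyl analogue stands apart.

The compounds shown leave open whether methoxy would behave the same way as 4-methoxyphenyl, and whether an amine, a carboxylic acid or a longer alkoxy chain on this phenyl ring would shift the number in either direction. No measurement given here explains any of these steps.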